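Cytotoxicity notes: nitro to trifluoromethyl

The source may hold more compounds than are shown below. What is called first, only, known or untested is meant among the compounds shown, and "the series" means these compounds.

In an ADME assay on MDCK cells (Canis lupus familiaris) for cytotoxicity, read by MTT assay, with a stated time of 24 h (a higher number here means that more compound is tolerated, a lower number that less compound is tolerated), compound 1 (`Cc1cc(CNS(=O)(=O)c2ccc(Br)cc2)c(C)o1`) gives 29600 nM, a measured number. Compound 2 (`O=[N+]([O-])c1ccc(S(=O)(=O)NCc2cc3ccccc3s2)cc1`) stands only at a limit of the assay, > 191000 nM, and has no number of its own.

Compound 3 (`O=S(=O)(NCc1cc2ccccc2s1)c1ccc(C(F)(F)F)cc1`) keeps the core of compound 2 and carries trifluoromethyl in place of nitro on an aromatic carbon, para to a large group: trifluoromethyl in place of nitro on an aromatic carbon. Among the compounds with values here, no measured pair in this set covers such a change, so the expectation rests on very little. Within the data shown here, the only number to lean on is that of compound 1 at 29600 nM. A modest move towards less compound tolerated is expected in this assay. The estimated step is an at least 1.9-fold lower number from compound 2 to compound 3 (0.28 log units; that floor lies within the scatter). Another reading at the limit would not be surprising. The expected value for compound 3 is 100000 nM, with an estimated range from 28000 nM to 200000 nM.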

Compound 3, half-maximal cytotoxic concentration: > 179000 nM
Compound 3 ended at the assay's limit (the forecaster's own chance of this, stated with the estimate: 45%); at least 1.7-fold (0.25 log units) between middle value and limit.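

Compound 2 and compound 3 both sit at limits of this assay, so the step between them cannot be read. The compounds shown leave open where either one's own value lies, and whether trifluoromethyl in place of nitro on an aromatic carbon changes the read-out at all.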